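The source may report more compounds than this note shows. Statements on the series, on what has been measured and on what is new or still open speak of the compounds shown alone.

Compound 3 `Cc1cc(CCC(=O)O)ccc1-c1noc(-c2ccc(OC(C)C)c(C#N)c2)n1` is followed in a functional assay on CHO cells with sphingosine 1-phosphate receptor 2 (Homo sapiens) as the target, read by GTPgammaS binding; on this read-out higher numbers stand for an effect only at larger amounts of compound and lower numbers for an effect already at smaller amounts. In this assay compound 3 gives only a limit, > 10000 nM. Its two neighbours share the same core and differ from it in one group on an aromatic carbon: compound 1 `Cc1cc(-c2nc(-c3ccc(CCC(=O)O)cc3C)no2)ccc1OC(C)C` carries a methyl there, compound 2 `Cc1cc(CCC(=O)O)ccc1-c1noc(-c2ccc(OC(C)C)c(Br)c2)n1` a bromo. Compound 1 also reaches only a limit, > 10000 nM. Compound 2 likewise reaches only a limit, > 10000 nM. The measured steps among these three are accordingly not readable: a step that the two limits leave unreadable from compound 1 to compound 2, a step that the two limits leave unreadable from compound 1 to compound 3 and a step that the two limits leave unreadable from compound 2 to compound 3. All three values rest at one and the same point, (the limit of > 10000 nM in this assay, at which 3 of the 3 values shown sit). Compound 4 `Cc1cc(CCC(=O)O)ccc1-c1noc(-c2ccc(OC(C)C(F)(F)F)c(C#N)c2)n1` differs from compound 3 by a single change, (trifluoromethyl in place of methyl on a saturated chain carbon bound to an oxygen on an aromatic ring and a saturated chain carbon). Within the data shown here, none of the measured steps touches this place, and none of them yields a size or direction, so nothing in the measured series points either way. Compound 4 is expected to give 15000 nM, with a range from 3000 nM to 60000 nM. The step this estimate implies from compound 3 to compound 4 is a step that the limit leaves unreadable from compound 3 to compound 4, expected to stay within the scatter, most likely again as a limit rather than a number.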

Compound 4, half-maximal effective concentration: > 10000 nM
Compound 4 was reported as a limit; the forecaster's own chance of this, stated with the estimate: 85%; the middle value is on the limit's open side.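

No new step can be read from compound 3 to compound 4, as both stand only as limits in this assay: the limit of > 10000 nM in this assay, at which 4 of the 4 values shown sit.

The compounds shown leave open whether trifluoromethyl in place of methyl, or any other change among these four compounds, alters the read-out at all.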